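Swapping a piperidinyl side chain for a carbamoyl group

The source may report more compounds than this note shows. Statements on the series, on what has been measured and on what is new or still open speak of the compounds shown alone.

Measured in a functional assay on LNCaP cells (Homo sapiens) for antiproliferative activity; a lower number here means a stronger inhibitor, a higher number a weaker inhibitor:
Compound 1 (`CNC(=O)C[C@@H]1C[C@@H](c2ccc(Cl)c(Cl)c2)[C@H](NC(=O)c2cc(-c3c(Cl)cnn3C)c(Cl)o2)CN1`): 40 nM
Compound 2 (`Cn1ncc(Cl)c1-c1cc(C(=O)N[C@@H]2CN[C@H](CCNS(C)(=O)=O)C[C@H]2c2ccc(F)c(F)c2)oc1Cl`): 50 nM
Compound 3 (`Cn1ncc(Cl)c1-c1cc(C(=O)N[C@@H]2CN[C@H](CCN3CCC(O)CC3)C[C@H]2c2ccc(Cl)c(Cl)c2)oc1Cl`): 1140 nM

Compound 3 has the highest number of the three in this assay, and so the weakest inhibition, at 1140 nM. Compound 4 (`Cn1ncc(Cl)c1-c1cc(C(=O)N[C@@H]2CN[C@H](CC(N)=O)C[C@H]2c2ccc(Cl)c(Cl)c2)oc1Cl`) has not yet been measured. It differs from compound 3 by one change (carbamoyl in place of (4-hydroxypiperidin-1-yl)methyl on a saturated chain carbon bound to a saturated ring carbon): carbamoyl in place of (4-hydroxypiperidin-1-yl)methyl on a saturated chain carbon bound to a saturated ring carbon.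

Among the measured compounds shown here, one measured step bears on this change: a 29-fold higher number from compound 1 to compound 3 (1.45 log units; beyond the scatter). That large step put (4-hydroxypiperidin-1-yl)methyl in place of methylcarbamoyl, so the change to compound 4 comes close to reversing it. For the measured compounds named here, no measured pair separates carbamoyl from methylcarbamoyl, which leaves the reversal incomplete. A large step to a lower number is therefore expected in this assay, estimated as a 16-fold lower number from compound 3 to compound 4 (1.21 log units; beyond the scatter). For compound 4 the estimated value is 70 nM, with an expected range from 20 nM to 250 nM.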

Compound 4, half-maximal inhibitory concentration: 160 nM
Compound 4: middle estimate off by 2.3-fold (0.36 log units), on the low side; measured number inside the range.
By their numbers in this assay, from the lowest: compounds 1 and 2 (each within the scatter of the next); then compound 4; then compound 3.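

In this assay the move to carbamoyl gives a 7.1-fold lower number from compound 3 to compound 4 (0.85 log units; beyond the scatter) and so wins back only part of what the (4-hydroxypiperidin-1-yl)methyl group had cost on this saturated chain carbon. Among the compounds shown here, the new compound also shows that the substituent on the amide-type nitrogen counts: hydrogen in place of methyl gives a 4.0-fold higher number from compound 1 to compound 4 (0.60 log units; beyond the scatter) and leaves the primary amide short of the methylcarbamoyl side chain, a gap the earlier compounds could not reveal. Nothing available here accounts for either step.

Still open, from the compounds shown here alone, is whether an ethyl or cyclopropyl group on that amide nitrogen would lower the number further or raise it again. Also open, going by these compounds, is how a carboxylic acid or a simple primary amine at the end of this side chain would compare with these amides.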